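The source may report more compounds than this note shows. Statements on the series, on what has been measured and on what is new or still open speak of the compounds shown alone.

Compound 1 `CCOC(=O)c1c(-c2ccc(C(F)(F)F)cc2)[nH]c2cccc(OC)c2c1=O` — 22000 nM
Compound 2 `CCOC(=O)c1c(-c2ccccc2)[nH]c2cc(OC)ccc2c1=O` — > 100000 nM

In a physicochemical assay for solubility, in phosphate buffer, at pH 7.4 (a higher number here means a more soluble compound, a lower number a less soluble compound), compound 1 gives 22000 nM. For compound 2 the reported value > 100000 nM is a limit of the assay and not a number (the limit of > 100000 nM in this assay, at which 1 of the 2 values shown sits). Compound 2 therefore stands at the top of what this assay reports, with compound 1 below it. Compound 3 `CCOC(=O)c1c(-c2cccc([N+](=O)[O-])c2)[nH]c2cc(OC)ccc2c1=O` differs from compound 2 by nitro in place of hydrogen on an aromatic carbon. Among the measured compounds shown here, no measured step covers this change; in this assay a decrease beyond the scatter is expected. For compound 3 the estimate is 50000 nM, range 15000 nM to 150000 nM, which means an expected step of an at least 2.0-fold lower number from compound 2 to compound 3 (0.30 log units; that floor lies within the scatter).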

Compound 3, solubility: 13000 nM
Compound 3: middle estimate off by 3.8-fold (0.59 log units), on the high side; the whole stated range lies above it.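

Nitro in place of hydrogen on an aromatic carbon, meta to a large group, gives an at least 7.6-fold lower number from compound 2 to compound 3 (0.88 log units; beyond the scatter). Among the compounds shown here, this is the first single-place step in this assay, and it shows that this position on the phenyl ring responds to substitution. Its true size remains unknown, and only a floor can be read: the limit of > 100000 nM in this assay, at which 1 of the 3 values shown sits.

On these data alone, how an amine or a carboxylic acid on the same carbon would compare with nitro remains open. So does the outcome for nitro on another carbon of that ring.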